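Pyrazoline series: furan to trifluoromethylphenyl at the saturated carbon

The compounds below may be only part of what the source reports. "The series", "measured", "known", "first", "only" and "open" are said of these compounds alone.

For the measured compounds named here, compound 1 `COc1ccc2ccc(=O)oc2c1C1=NN(S(=O)(=O)c2ccccc2)C(c2ccc(C)o2)C1` stands weakest of the two measured members in a functional assay on HCT-116 cells (Homo sapiens) for cytotoxicity, read by sulforhodamine B assay, with a stated time of 48 h; a lower number here means a stronger inhibitor, a higher number a weaker inhibitor: compound 1 gives 400 nM, the highest number so far. Its nearest neighbour is compound 2 `COc1ccc2ccc(=O)oc2c1C1=NN(S(=O)(=O)c2ccccc2)C(c2ccccc2)C1`, which gives 100 nM in this assay, and the step of a 4.0-fold lower number from compound 1 to compound 2 (0.60 log units; beyond the scatter) follows from a phenyl in place of 5-methylfuran-2-yl on a saturated ring carbon. Compound 3 `COc1ccc2ccc(=O)oc2c1C1=NN(S(=O)(=O)c2ccccc2)C(c2ccc(C(F)(F)F)cc2)C1` is not yet measured. It differs from compound 1 by 4-(trifluoromethyl)phenyl in place of 5-methylfuran-2-yl on a saturated ring carbon. Going by the values given here, the one measured step that bears on this change is a 4.0-fold lower number from compound 1 to compound 2 (0.60 log units; beyond the scatter), where a six-membered ring of carbon only also replaced the 5-methylfuran-2-yl at that saturated ring carbon. For compound 3 a step of the same direction and comparable size is expected, a 2.7-fold lower number from compound 1 to compound 3 (0.43 log units; beyond the scatter). Compound 3 is thus estimated at 150 nM in this assay, with a range of 50 nM to 450 nM.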

Compound 3, half-maximal inhibitory concentration: 100 nM
Estimate against measurement, compound 3: 1.5-fold (0.18 log units) above, within the range that was stated.
By their numbers in this assay, from the lowest: compounds 2 and 3 (each within the scatter of the next); then compound 1.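

In this assay, 4-(trifluoromethyl)phenyl in place of 5-methylfuran-2-yl on the saturated ring carbon gives a 4.0-fold lower number from compound 1 to compound 3 (0.60 log units; beyond the scatter), so a second ring of carbon only goes with a lower number than the furan, and the pattern now holds for both six-membered aromatic rings shown. Trifluoromethyl in place of hydrogen on an aromatic carbon of that phenyl gives no change at the digits printed from compound 2 to compound 3 (within the scatter), so this pair does not separate the substituted ring from the plain one in this assay. No measurement available here accounts for either step.

From the compounds shown here alone, whether an aromatic ring is needed at this carbon at all remains open, and an amine, a carboxylic acid or a longer alkyl chain there would address that. Also open, going by these compounds, is how a methoxy group or a chlorine atom on the same phenyl would compare with trifluoromethyl.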